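The compounds below may be only part of what the source reports. "The series", "measured", "known", "first", "only" and "open" are said of these compounds alone.

Within the data shown here, in an ADME assay on MT4 cells (Homo sapiens) for cytotoxicity, read by MTT assay, with a stated time of 4 days (a lower number here means that less compound is tolerated, a higher number that more compound is tolerated), compound 1 (`Cc1ccc(-c2c(C)c(-c3ccc4c(c3C)CCCO4)c(C(OC(C)(C)C)C(=O)O)c(C)c2NS(C)(=O)=O)cc1C`) gives 24000 nM and compound 2 (`CC(=O)Nc1c(C)c(C(OC(C)(C)C)C(=O)O)c(-c2ccc(C)c(C)c2)c(C)c1-c1ccc(C)c(C)c1`) gives 19000 nM with the two values within the scatter of each other, so compound 1 stands level with the only other number in hand. Compound 3 (`Cc1ccc(-c2c(C)c(-c3ccc(Cl)cc3)c(C(OC(C)(C)C)C(=O)O)c(C)c2NS(C)(=O)=O)cc1C`) keeps the core of compound 1 and exchanges one group: a group of 7 heavy atoms (6 carbon, 1 chlorine; one six-membered aromatic ring of carbon only) in place of a group of 11 heavy atoms (10 carbon, 1 oxygen; one six-membered non-aromatic ring with 1 hetero atom, one six-membered aromatic ring of carbon only), on an aromatic carbon with the incoming 4-chlorophenyl para to a methanesulfonamido group and ortho to a carboxy(tert-butoxy)methyl group. Among the measured compounds shown here, no measured pair shows this exchange, so the data give no direct guide to it. No step beyond the scatter is expected in this assay in either direction. The estimated step is a 1.1-fold lower number from compound 1 to compound 3 (0.04 log units; within the scatter) and stays within the scatter. For compound 3 the expected value is 22000 nM with an estimated range from 10000 nM to 45000 nM in this read-out.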

Compound 3, half-maximal cytotoxic concentration: 26000 nM
Estimate against measurement, compound 3: 1.2-fold (0.07 log units) below; measured number inside the range.
By their numbers in this assay, from the lowest: compounds 2, 1 and 3 (each within the scatter of the next).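

In this assay, among these compounds, the aromatic carbon para to a methanesulfonamido group takes 4-chlorophenyl in place of the group of 11 heavy atoms with a 1.1-fold higher number from compound 1 to compound 3 (0.03 log units; within the scatter), the only one-place comparison so far. At this position, then, the non-aromatic ring with its hetero atom and the hydrogen-bond acceptor can give way to a chlorine-bearing phenyl ring without a step beyond the scatter in this read-out. Nothing in hand accounts for this result.

On these data alone, whether an amine or a carboxylic acid on the incoming phenyl ring, or a plain methyl group at this position, would give a step beyond the scatter stays open. Also open, as far as these compounds go, is whether the same exchange behaves alike with a group other than methanesulfonamido on the shared core.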